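The source may hold more compounds than are shown below. What is called first, only, known or untested is meant among the compounds shown, and "the series" means these compounds.

Measured compounds in a functional assay on MDA-MB-231 cells (Homo sapiens) for antiproliferative activity, with a stated time of 4 days; on this read-out higher numbers stand for weaker inhibition and lower numbers for stronger inhibition:
compound 1, `CCCCc1ccc2[nH]c(-c3ccc(OC)cc3)c(/C=N/NC(=O)c3ccc(OC)cc3)c2c1`, gives 61 nM
compound 2, `CCCCc1ccc2[nH]c(-c3ccc(C(F)(F)F)cc3)c(/C=N/NC(=O)c3ccc(OC)cc3)c2c1`, gives 284 nM
compound 3, `CCCCc1ccc2[nH]c(-c3ccc(OC)cc3)c(/C=N/NC(=O)c3ccccn3)c2c1`, gives 34 nM

Compound 4, `CCCCc1ccc2[nH]c(-c3ccc(C(F)(F)F)cc3)c(/C=N/NC(=O)c3ccccn3)c2c1`, is not yet measured. It differs from compound 3 by trifluoromethyl in place of methoxy on an aromatic carbon. The same change is made from compound 1 to compound 2, (trifluoromethyl in place of methoxy on an aromatic carbon), and that step gave a 4.7-fold higher number from compound 1 to compound 2 (0.67 log units; beyond the scatter). The two places agree word for word, but the cores carrying the change differ by pyridin-2-yl in place of 4-methoxyphenyl on a carbonyl carbon, a difference whose own step was a 1.8-fold lower number from compound 1 to compound 3 (0.25 log units; within the scatter); the change is thus treated as the same kind of change rather than the same. Because the earlier step of a 4.7-fold higher number from compound 1 to compound 2 (0.67 log units; beyond the scatter) lay beyond the scatter, a step of similar size is expected for compound 4, a 4.7-fold higher number from compound 3 to compound 4 (0.67 log units; beyond the scatter), resting on a single prior instance. Compound 4 is estimated at 160 nM, expected between 60 nM and 420 nM.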

Compound 4, half-maximal inhibitory concentration: 260 nM
The estimate for compound 4 lay 1.6-fold (0.21 log units) below the measured number, within the range that was stated.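

In this assay, trifluoromethyl in place of methoxy again gives a higher number (a 7.6-fold higher number from compound 3 to compound 4 (0.88 log units; beyond the scatter)), and the step carries from the core of compound 1 to the core of compound 3: the same change on two cores in this assay, a 4.7-fold higher number (0.67 log units; beyond the scatter) from compound 1 to compound 2 and a 7.6-fold higher number (0.88 log units; beyond the scatter) from compound 3 to compound 4, 1.6-fold (0.22 log units) apart, within the scatter of two such steps. Pyridin-2-yl in place of 4-methoxyphenyl on the carbonyl carbon stays within the scatter with trifluoromethyl present (a 1.1-fold lower number from compound 2 to compound 4 (0.04 log units; within the scatter)), in line with its earlier step: the same change on two cores in this assay, a 1.8-fold lower number (0.25 log units; within the scatter) from compound 1 to compound 3 and a 1.1-fold lower number (0.04 log units; within the scatter) from compound 2 to compound 4, 1.6-fold (0.22 log units) apart, within the scatter of two such steps. These four compounds show the two changes acting separately on two cores in one cell assay only, and they do not show that the step holds on other cores or in other assays.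

Still open, on these data alone, is whether a nitrile or an amine on that aromatic carbon would track methoxy or trifluoromethyl. Also open, as far as these compounds go, is whether the step survives with a group other than pyridin-2-yl or 4-methoxyphenyl on the carbonyl carbon.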